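A few compounds are considered here, and "the series" means these few. Any claim that something is new, unique, unknown or untested is made for them only; others in the source may bear on it.

Measured so far:
Compound 1, `Cc1ncc([N+](=O)[O-])n1CCOC(=O)c1cc(NC(=O)C(C)NC(=O)OCc2ccccc2)ccc1O`: 47%
Compound 2, `Cc1ncc([N+](=O)[O-])n1CCOC(=O)c1cc(NC(=O)[C@@H](NC(=O)OCc2ccccc2)C(C)C)ccc1O`: 64.5%

In a functional assay on the whole organism (strain Wistar) for inhibition, with Rattus norvegicus as the target, read by paw edema, with stated times of 1 h and 2 h, at a dose of 10 mg/kg by the intraperitoneal route (a lower number here means less inhibition, a higher number more inhibition at the dose given (going by the name of the read-out)), compound 2 gives 64.5%, the higher of the two numbers obtained so far; compound 1 gives 47%, lower by a margin beyond the usual scatter. Compound 3, `Cc1ncc([N+](=O)[O-])n1CCOC(=O)c1cc(NC(=O)CNC(=O)OCc2ccccc2)ccc1O`, is not yet measured. It differs from compound 2 as follows: hydrogen in place of isopropyl on a saturated chain carbon bound to an amide-type nitrogen and a carbonyl carbon. Going by the values given here, with two measured compounds and no computed step between them, no firm pattern can be drawn; what the two values show is that the compound carrying isopropyl on the saturated chain carbon bound to an amide-type nitrogen and a carbonyl carbon gives the higher number and compound 1 the lower one. Removing the group altogether is expected to move the number downward, by a step of moderate size, probably beyond the scatter. Compound 3 is expected to give about 40%, within 25% to 55%. The expected change is a number 24.5 percentage points lower from compound 2 to compound 3 (beyond the scatter).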

Compound 3, a percentage reported as inhibition, in the whole organism at one dose (the size of the read-out at that dose, not a potency): 56.5%
The estimate for compound 3 lay 16.5 percentage points below the measured number; the measured number lies above the stated range.
By their numbers in this assay, from the lowest: compounds 1, 3 and 2 (each within the scatter of the next, the first and the last beyond it).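

In this assay, the saturated chain carbon bound to an amide-type nitrogen and a carbonyl carbon now has a member carrying hydrogen alone, and the two new steps are a number 8 percentage points lower from compound 2 to compound 3 (within the scatter) and a number 9.5 percentage points higher from compound 1 to compound 3 (within the scatter). Hydrogen at this place therefore cannot be told apart from either isopropyl or methyl, even though compound 1 at 47% and compound 2 at 64.5% lie beyond the scatter of each other, so the three compounds give no graded series running through hydrogen. Nothing available on these compounds accounts for this result.

Going by these compounds, what a longer chain, an amine or a carboxylic acid on this carbon would give remains open. Also open, on these data alone, is whether the gap between compound 1 and compound 2 would hold at another dose.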